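A smaller amide side chain on compound 2

A few compounds are considered here, and "the series" means these few. Any claim that something is new, unique, unknown or untested is made for them only; others in the source may bear on it.

In an in vitro ADME assay on microsomes from Gut (Homo sapiens) for metabolic stability, in the presence of a further agent that is not named here (on this read-out lower numbers stand for slow clearance and higher numbers for fast clearance), compound 1 (`COc1ccc(Cl)cc1Cn1c(C(=O)NCC(C)(C)CO)cc2cc(C#N)ccc21`) gives 63 mL.min-1.g-1, compound 2 (`COc1ccc(Br)cc1Cn1c(C(=O)NCC(C)(C)CO)cc2cc(C#N)ccc21`) gives 94 mL.min-1.g-1 and compound 3 (`Cc1ccc(Cl)cc1Cn1c(C(=O)NCC(C)(C)CO)cc2cc(C#N)ccc21`) gives 124 mL.min-1.g-1. The step of a 1.5-fold higher number from compound 1 to compound 2 (0.17 log units; within the scatter) and the step of a 1.3-fold higher number from compound 2 to compound 3 (0.12 log units; within the scatter) place compound 2 within the scatter of both others. Compound 4 (`COc1ccc(Br)cc1Cn1c(C(=O)NCCCO)cc2cc(C#N)ccc21`) differs from compound 2 in the amide side chain: 2-hydroxyethyl in place of 1-(hydroxymethyl)-1-methylethyl on a saturated chain carbon bound to an amide-type nitrogen. Those two steps, like the step of a 2.0-fold higher number from compound 1 to compound 3 (0.29 log units; within the scatter), exchange only groups outside this chain, so no measurement tests the change directly. No shift beyond the scatter is therefore expected, and the estimated step is a 1.2-fold lower number from compound 2 to compound 4 (0.07 log units; within the scatter). Compound 4 is expected at 80 mL.min-1.g-1, within an estimated range of 40 mL.min-1.g-1 to 160 mL.min-1.g-1.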

Compound 4, intrinsic clearance in microsomes: < 6 mL.min-1.g-1
Compound 4: a limit, no number; the forecaster's own chance of this, stated with the estimate: 3%; middle value at least 13-fold (1.12 log units) away from the limit.
By their numbers in this assay, from the lowest: compounds 1, 2 and 3 (each within the scatter of the next). At a limit, below all of these: compound 4.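

Among the compounds shown, the amide side chain is the only place where a single change moves the read-out beyond the scatter: 3-hydroxypropyl in place of 2-(hydroxymethyl)-2-methylpropyl gives an at least 15-fold lower number from compound 2 to compound 4 (1.19 log units; beyond the scatter). This change removes 2 heavy atoms and leaves the hydrogen-bond donor and acceptor counts as they were. In this assay, compound 4 gives < 6 mL.min-1.g-1, which is a limit and not a number: the limit of < 6 mL.min-1.g-1 in this assay, at which 1 of the 4 values shown sits.

The compounds shown leave open whether a longer chain, an amine or a carboxylic acid in place of 3-hydroxypropyl would keep so low a number. They also leave open whether the same change would give a step of this size on compound 1 or compound 3.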